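This account rests on a few compounds, and the source may have more. Where it says the series, first, only, none or still open, it means among the compounds named here.

Measured compounds in a functional assay on UO-31 cells (Homo sapiens) for inhibition, read by sulforhodamine B assay, with a stated time of 48 h; a lower number here means that less compound is tolerated, a higher number that more compound is tolerated:
- Compound 1, `COc1cc(-c2nn(-c3cccc(NC(=O)Nc4ccc(Cl)c(Cl)c4)c3)cc2-c2ccncc2)ccc1Cl`; compound 1 gives > 50000 nM, which is a limit of the assay.
- Compound 2, `O=C(Nc1cccc(-n2cc(-c3ccncc3)c(-c3ccc(Cl)c(O)c3)n2)c1)Nc1ccc(Cl)c(Cl)c1`; compound 2 gives > 32500 nM, likewise a limit.
- Compound 3, `O=C(Nc1cccc(-n2cc(-c3ccncc3)c(-c3ccc(Cl)c(O)c3)n2)c1)Nc1cc(C(F)(F)F)cc(C(F)(F)F)c1`; compound 3 gives 6600 nM.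

Compound 1 therefore stands at the limit of > 50000 nM in this assay, at which 1 of the 3 values shown sits, with no number of its own. For the measured compounds named here, its one measured step, a step that the two limits leave unreadable from compound 1 to compound 2, cannot be read because compound 2 stands at the limit of > 32500 nM in this assay, at which 1 of the 3 values shown sits. Going by the values given here, compound 2 and compound 3 carry different groups on the outer urea nitrogen; for that pair no step is given, and their two values show only a limit for one and a number for the other.

Compound 4, `COc1cc(-c2nn(-c3cccc(NC(=O)c4ccccc4)c3)cc2-c2ccncc2)ccc1Cl`, differs from compound 1 by phenyl in place of (3,4-dichlorophenyl)amino on a carbonyl carbon, so the urea of compound 1 becomes a benzamide. Among the compounds with values here, no measured step touches this change, and the single step starting from compound 1 is unreadable. The author therefore has no ground to expect movement in this assay and expects a number no higher from compound 1 to compound 4 (the limit leaves the size open) to be no step beyond the scatter, with compound 4 most likely remaining at a limit. The estimate for compound 4 is 50000 nM, within a range from 15000 nM to 100000 nM.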

Compound 4, concentration lethal to 50% of the cells: > 100000 nM
Compound 4 gave a limit, no number; the forecaster's own chance of this, stated with the estimate: 70%; middle value at least 2.0-fold (0.30 log units) from the limit.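

Compound 4 in this assay gives > 100000 nM, which is a limit and not a number. For the compounds shown here, compound 1 also stands at a limit, so no step from it to compound 4 can be read. The compounds shown leave open whether phenyl in place of (3,4-dichlorophenyl)amino on a carbonyl carbon shifts the read-out at all, and in which direction.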